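Taking the chlorine off compound 2

The source may report more compounds than this note shows. Statements on the series, on what has been measured and on what is new or still open speak of the compounds shown alone.

In a functional assay on A549 cells (Homo sapiens) for antiproliferative activity, read by CCK-8 assay, with a stated time of 72 h (on this read-out lower numbers stand for stronger inhibition and higher numbers for weaker inhibition), compound 1 `Nc1ccccc1NC(=O)c1ccc(COc2ccc(Br)cc2)cc1` gives 24400 nM as a measured number. Compound 2 `Nc1ccccc1NC(=O)c1ccc(COc2ccc(Cl)cc2)cc1` stands at > 32000 nM as a limit of the assay, not a number. Compound 3 `Nc1ccccc1NC(=O)c1ccc(COc2ccccc2)cc1` differs from compound 2 by one small edit: hydrogen in place of chloro on an aromatic carbon with hydrogen in place of chloro on an aromatic carbon, para to a large group. Among the measured compounds shown here, the one measured step that bears on this edit swaps bromo for chloro on an aromatic carbon, and it reads an at least 1.3-fold higher number from compound 1 to compound 2 (0.11 log units; that floor lies within the scatter) in the same test. For the measured compounds named here, that step gives no firm trend, and no measurement yet shows the effect of having no halogen there, so no step beyond the scatter is expected in this assay in either direction. The expected step is an at least 1.0-fold lower number from compound 2 to compound 3 (0.02 log units; that floor lies within the scatter) on this estimate. Compound 3 is estimated at 30000 nM within an expected range from 13000 nM to 64000 nM for repeated measurements.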

Compound 3, half-maximal inhibitory concentration: 6760 nM
Estimate against measurement, compound 3: 4.4-fold (0.65 log units) above; measured number below the stated range.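

In this assay, taking the halogen away turns out to matter: going from 4-chlorophenoxy to phenoxy gives an at least 4.7-fold lower number from compound 2 to compound 3 (0.67 log units; beyond the scatter), and hydrogen in place of bromo gives a 3.6-fold lower number from compound 1 to compound 3 (0.56 log units; beyond the scatter). The earlier bromo-to-chloro step gave no firm trend, but these two steps show that this place on the ring is not indifferent, and compound 3, with hydrogen there, is the strongest of the three. The size of the first step is only a floor, since compound 2 carries a limit and not a number: the limit of > 32000 nM in this assay, at which 1 of the 3 values shown sits.

On these data alone, whether a fluorine, a methoxy group or an amine at this place would behave like hydrogen or like the larger halogens stays open. The values also do not tell why hydrogen does better here, and they speak for this one place only.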